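The source may hold more compounds than are shown below. What is called first, only, known or untested is meant among the compounds shown, and "the series" means these compounds.

Measured so far in a functional assay on HeLa cells (Homo sapiens) for inhibition, read by sulforhodamine B assay, with a stated time of 48 h; on this read-out lower numbers stand for stronger inhibition of growth and higher numbers for weaker inhibition of growth:
compound 1 `O=C(N/N=C\c1ccc(Cl)cc1)C1=C(Cl)c2ccccc2CCC1`: 2300 nM
compound 2 `Cc1ccc(C(=O)N/N=C/C2=C(Cl)c3ccccc3CCC2)cc1`: 300 nM
compound 3 `O=C(N/N=C/C1=C(Cl)c2ccccc2CCC1)c1ccc([N+](=O)[O-])cc1`: > 100000 nM

All three share one core and differ only in the aryl group attached to the acylhydrazone. Among the two numbers reported, compound 2 stands lowest, with 300 nM, while compound 1 gives the higher number 2300 nM. For compound 3 the result is not a number but a limit of the assay, > 100000 nM, which is the limit of > 100000 nM in this assay, at which 1 of the 3 values shown sits.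

Compound 4 `O=C(N/N=C/C1=C(Cl)c2ccccc2CCC1)c1cccc(I)c1` has not been measured. It differs from compound 2 in one place: 3-iodophenyl in place of 4-methylphenyl on a carbonyl carbon. Going by the values given here, the only measured step on that same ring position is an at least 330-fold higher number from compound 2 to compound 3 (2.52 log units; beyond the scatter), where exchanging the methyl for a nitro group cost a large amount of activity. Among the compounds with values here, that step replaced the methyl with a very different group; a 3-iodophenyl is a different change again, and no measured pair shows how this assay responds to iodine on that ring. Within the data shown here, the single step on record points to loss of activity when the methyl leaves, so a weaker result is expected for compound 4 than for compound 2, but with wide uncertainty. Compound 4 is therefore estimated at 2500 nM, between 300 nM and 30000 nM, which would mean a step of an 8.3-fold higher number from compound 2 to compound 4 (0.92 log units; beyond the scatter).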

Compound 4, concentration for 50% growth inhibition: 6300 nM
The estimate for compound 4 lay 2.5-fold (0.40 log units) below the measured number; low and high end bracket the measured number.
By their numbers in this assay, from the lowest: compound 2; then compound 1; then compound 4. At a limit, above all of these: compound 3.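

Compound 4 shows that the loss of activity seen with the nitro group in compound 3 is not a one-off, since a second replacement of the 4-methylphenyl on the carbonyl carbon also weakens growth inhibition in this assay, with a 21-fold higher number from compound 2 to compound 4 (1.32 log units; beyond the scatter). This change keeps the count of heavy atoms, the carbon-only aromatic ring and the absence of hydrogen-bond donors and acceptors, so those counts alone do not preserve the activity of compound 2. The step also differs from the nitro change in one respect: compound 4 still gives a readable number rather than a limit of the assay, yet nothing measured here explains the drop in activity or why the two replacements differ in this way.

This change moved the substituent on the ring and swapped methyl for iodine at once, so the compounds shown cannot say which of the two matters, and a 3-methylphenyl or a 4-iodophenyl group would pull them apart. Also open, as far as these compounds go, is whether any group on this ring can improve on the methyl of compound 2, for example an ethyl chain, a methoxy group or an amine.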